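Sulfamoyl for hydroxy on the propyl-bearing core

The source may report more compounds than this note shows. Statements on the series, on what has been measured and on what is new or still open speak of the compounds shown alone.

Four compounds share one core and differ at two places. Compound 1 `Cn1nc(-c2ccnc(Nc3ccc(O)cc3)n2)c2ccccc21` carries the hydroxy group on the methyl-bearing core; in a functional assay on MCF7 cells (Homo sapiens) for antiproliferative activity, read by MTT assay, with a stated time of 72 h (on this read-out lower numbers stand for stronger inhibition of growth and higher numbers for weaker inhibition of growth), compound 1 gives 8910 nM. Compound 2 `Cn1nc(-c2ccnc(Nc3ccc(S(N)(=O)=O)cc3)n2)c2ccccc21` differs from compound 1 by sulfamoyl in place of hydroxy on an aromatic carbon and in this assay compound 2 gives 940 nM; the step is a 9.5-fold lower number from compound 1 to compound 2 (0.98 log units; beyond the scatter). Compound 3 `CCCn1nc(-c2ccnc(Nc3ccc(O)cc3)n2)c2ccccc21` differs from compound 1 only at the core: ethyl in place of hydrogen on a saturated chain carbon bound to an aromatic nitrogen. In this assay compound 3 gives 3340 nM, a step of a 2.7-fold lower number from compound 1 to compound 3 (0.43 log units; beyond the scatter).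

Compound 4 `CCCn1nc(-c2ccnc(Nc3ccc(S(N)(=O)=O)cc3)n2)c2ccccc21` is not yet measured; it differs from compound 3 by sulfamoyl in place of hydroxy on an aromatic carbon. The place of this change is the same, word for word, as for the change from compound 1 to compound 2, so it is the same change carried onto the propyl-bearing core. It occurs twice among these compounds, and only the instance between compound 1 and compound 2 has both ends measured; nothing shows whether its size depends on which core carries it.

The expectation for compound 4 in this assay is 350 nM, with the range 150 nM to 900 nM expected to hold it. This rests on compound 3 at 3340 nM and on the step of a 9.5-fold lower number from compound 1 to compound 2 (0.98 log units; beyond the scatter) being carried over, which means an expected step of a 9.5-fold lower number from compound 3 to compound 4 (0.98 log units; beyond the scatter). If that step transfers, compound 4 is expected to return the lowest number of the four.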

Compound 4, concentration for 50% growth inhibition: 590 nM
Compound 4: the middle estimate sits 1.7-fold (0.23 log units) below what was measured; the range from low to high includes it.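

In this assay the sulfamoyl change on the propyl-bearing core gives a 5.7-fold lower number from compound 3 to compound 4 (0.75 log units; beyond the scatter), and its size does not differ from that on the methyl-bearing core: the same change on two cores in this assay, a 9.5-fold lower number (0.98 log units; beyond the scatter) from compound 1 to compound 2 and a 5.7-fold lower number (0.75 log units; beyond the scatter) from compound 3 to compound 4, 1.7-fold (0.22 log units) apart, within the scatter of two such steps. Read the other way, the core change on the sulfamoyl pair gives a 1.6-fold lower number from compound 2 to compound 4 (0.20 log units; within the scatter), a step that by itself lies within the scatter, though it does not differ from the same change on the hydroxy pair: the same change on two cores in this assay, a 2.7-fold lower number (0.43 log units; beyond the scatter) from compound 1 to compound 3 and a 1.6-fold lower number (0.20 log units; within the scatter) from compound 2 to compound 4, 1.7-fold (0.22 log units) apart, within the scatter of two such steps. The two changes therefore add up within the scatter on these four compounds, which supports carrying the sulfamoyl change between these two cores, but this rests on one pair of cores in one assay and gives no reason for the size of either step.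

As far as these compounds go, it stays open whether the sulfamoyl step keeps its size with a longer chain or a benzyl group on the aromatic nitrogen in place of propyl. From the compounds shown here alone, it also stays open how a carboxylic acid or an amine would read on the same aromatic carbon in place of sulfamoyl, on either core.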